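This account rests on a few compounds, and the source may have more. Where it says the series, first, only, none or still open, it means among the compounds named here.

Among the three compounds measured so far in a physicochemical assay for lipophilicity, read by HPLC, at pH 7.4 (a lower number here means a more polar compound, a higher number a more lipophilic compound), compound 3 (`CNCc1cn(S(=O)(=O)c2ncccc2C)c(-c2cccnc2F)c1F`) stands highest at 0.32, beyond the scatter from both of the others. Compound 1 (`CNCc1cc(-c2cccnc2F)n(S(=O)(=O)c2ccsc2)c1`) gives -0.83 and compound 2 (`CNCc1cc(-c2cccnc2F)n(S(=O)(=O)c2cccs2)c1`) gives -0.69.

Compound 4 (`CNCc1cn(S(=O)(=O)c2cccnc2C)c(-c2cccnc2F)c1F`) has the same atoms as compound 3, joined differently: 2-methylpyridin-3-yl in place of 3-methylpyridin-2-yl on a sulfonyl sulfur. It carries 2-methylpyridin-3-yl in place of 3-methylpyridin-2-yl on a sulfonyl sulfur.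

Among the compounds with values here, one measured step bears on this change, the exchange of thiophen-3-yl for thiophen-2-yl on a sulfonyl sulfur. It also keeps the atoms the same, and it gives a number 0.14 log units higher from compound 1 to compound 2 (within the scatter). Within the data shown here, no measured pair of methylpyridinyl isomers exists, so this precedent is indirect and the range stays wide.

On that evidence, no shift beyond the scatter is expected in this assay, and the estimated change is small and slightly downward, a number 0.12 log units lower from compound 3 to compound 4 (within the scatter). Compound 4 is expected at 0.2, within an estimated range of -0.25 to 0.65.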

Compound 4, distribution coefficient: 0.48
Beside the measured number, compound 4's estimate is 0.28 log units below it, and the stated range covers the measured number.
By their numbers in this assay, from the lowest: compounds 1 and 2 (each within the scatter of the next); then compounds 3 and 4 (each within the scatter of the next).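

In this assay, putting 2-methylpyridin-3-yl in place of 3-methylpyridin-2-yl on a sulfonyl sulfur gives a number 0.16 log units higher from compound 3 to compound 4 (within the scatter), so the two isomers cannot be told apart by this read-out. The earlier compounds shown here held no methylpyridinyl pair, only the thiophene pair with its step of a number 0.14 log units higher from compound 1 to compound 2 (within the scatter), and both exchanges of the same atoms at this place now stay within the scatter. Nothing measured here gives a cause for this result.

Compounds 3 and 4 differ from compounds 1 and 2 in more than one place, so their higher numbers cannot be assigned to any single group. Going by these compounds, how a plain phenyl ring, or a pyridine ring carrying a carboxylic acid or an amine, would read on this sulfonyl sulfur remains open.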